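The compounds below may be only part of what the source reports. "The series", "measured", "known", "first", "only" and "open" are said of these compounds alone.

Of the compounds shown here, two have so far been measured in a functional assay for inhibition, with Homo sapiens as the target; on this read-out higher numbers stand for weaker inhibition and lower numbers for stronger inhibition. Compound 1 `COc1ccc(Nc2nccc(-c3cccnc3)n2)cc1` gives 1700 nM in this assay. Compound 2 `Cc1cc(-c2ccnc(Nc3ccc(N(C)C)cc3)n2)c(C)o1` gives 4900 nM in this assay, the higher of the two numbers, and its gap to compound 1 is beyond the usual scatter, so compound 2 is the weaker inhibitor of the pair. Compound 3 `CN(C)c1ccc(Nc2nccc(-c3cccnc3)n2)cc1` has not been measured yet. It differs from compound 2 in one place: pyridin-3-yl in place of 2,5-dimethylfuran-3-yl on an aromatic carbon. Compound 3 thereby carries the same pyridin-3-yl group as compound 1, and compound 1 gives 1700 nM in this assay, which points to a lower number for compound 3 than for compound 2. A modest step toward stronger inhibition is expected, a 2.5-fold lower number from compound 2 to compound 3 (0.39 log units; beyond the scatter), though it may fall inside the scatter. The estimate for compound 3 is 2000 nM, with a range from 700 nM to 6000 nM.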

Compound 3, half-maximal inhibitory concentration: 2800 nM
The estimate for compound 3 lay 1.4-fold (0.15 log units) below the measured number; the measured number falls inside the stated range.
By their numbers in this assay, from the lowest: compounds 1, 3 and 2 (each within the scatter of the next, the first and the last beyond it).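

In this assay, pyridin-3-yl in place of 2,5-dimethylfuran-3-yl, on the aromatic carbon next to the ring nitrogen, gives a 1.8-fold lower number from compound 2 to compound 3 (0.24 log units; within the scatter) so at this position the two rings cannot be told apart in this read-out. Dimethylamino in place of methoxy on an aromatic carbon gives a 1.6-fold higher number from compound 1 to compound 3 (0.22 log units; within the scatter) and so cannot be told apart from the scatter either, which means that compound 3 links the two earlier compounds through two single changes, neither of them a clear step. No measurement here offers an explanation for the size of these steps.

The compounds shown leave open whether a simple methyl group or an unsubstituted phenyl ring at this position would shift the number beyond the scatter. The same question stands for a morpholine group in place of dimethylamino.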